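The compounds below may be only part of what the source reports. "The series", "measured", "known", "first", "only" and "open" are said of these compounds alone.

Measured so far:
compound 1 `CNC(=O)c1cc(Oc2ccc(NC(=O)c3cc(-c4ccc(Cl)cc4)ncn3)cc2F)ccn1`: > 100000 nM
compound 2 `CCc1ccc(-c2cc(C(=O)Nc3ccc(Oc4ccnc(C(=O)NC)c4)c(F)c3)ncn2)cc1`: 3390 nM

In a functional assay on A549 cells (Homo sapiens) for cytotoxicity, read by MTT assay, with a stated time of 72 h (a higher number here means a weaker inhibitor, a lower number a stronger inhibitor), compound 1 reaches only a limit of the assay, > 100000 nM. Compound 2 gives 3390 nM in this assay, the only plain number shown. The other value is a limit (the limit of > 100000 nM in this assay, at which 1 of the 2 values shown sits). Among the compounds with values here, the single measured step is an at least 29-fold lower number from compound 1 to compound 2 (1.46 log units; beyond the scatter). Compound 3 `CNC(=O)c1cc(Oc2ccc(NC(=O)c3cc(-c4ccc(C)cc4)ncn3)cc2F)ccn1` differs from compound 2 by hydrogen in place of methyl on a saturated chain carbon bound to an aromatic carbon. The measured step exchanged chloro for ethyl, a change of kind; trimming ethyl to methyl is smaller, so a modest weakening is expected, a 2.4-fold higher number from compound 2 to compound 3 (0.37 log units; beyond the scatter). Compound 3 is estimated at 8000 nM, with a range from 2000 nM to 40000 nM.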

Compound 3, half-maximal inhibitory concentration: 13200 nM
Estimate against measurement, compound 3: 1.7-fold (0.22 log units) below, and the stated range covers the measured number.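

Trimming ethyl to methyl gives a 3.9-fold higher number from compound 2 to compound 3 (0.59 log units; beyond the scatter), so even one carbon at this place changes the result, and the gain over chloro is not simply all-or-nothing. Methyl in place of chloro still gives an at least 7.5-fold lower number from compound 1 to compound 3 (0.87 log units; beyond the scatter), so both compounds carrying a saturated chain stand apart from compound 1, with ethyl ahead of methyl. Steps from compound 1 are only bounds because its value is a limit: the limit of > 100000 nM in this assay, at which 1 of the 3 values shown sits.

From the compounds shown here alone, whether a longer chain such as propyl would continue this trend stays open, as does the effect of an amine or a carboxylic acid at this place.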